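Methyl on the aromatic nitrogen of compound 3

A few compounds are considered here, and "the series" means these few. Any claim that something is new, unique, unknown or untested is made for them only; others in the source may bear on it.

In a functional assay on MCF7 cells (Homo sapiens) for antiproliferative activity, read by MTT assay, with a stated time of 48 h (a lower number here means a stronger inhibitor, a higher number a weaker inhibitor), compound 1 `COc1cc(-c2nnc3c(OC)cc(-c4ccc5[nH]ccc5c4)cn23)cc(OC)c1OC` gives 80 nM, and compound 2 `COc1cc(-c2nnc3c(OC4COC4)cc(-c4ccc5[nH]ccc5c4)cn23)cc(OC)c1OC` gives 2470 nM. Compound 3 `COc1cc(-c2nnc3c(OC)cc(-c4ccc5[nH]cc(C=O)c5c4)cn23)cc(OC)c1OC` gives > 10000 nM, which is a limit of the assay and not a number. Compound 3 stands at the limit of > 10000 nM in this assay, at which 1 of the 3 values shown sits.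

Compound 4 `COc1cc(-c2nnc3c(OC)cc(-c4ccc5c(c4)c(C=O)cn5C)cn23)cc(OC)c1OC` differs from compound 3 by one change: methyl in place of hydrogen on an aromatic nitrogen. Within the data shown here, no measured step covers methyl in place of hydrogen on an aromatic nitrogen. Two large steps bear on it only indirectly: a 31-fold higher number from compound 1 to compound 2 (1.49 log units; beyond the scatter) and an at least 120-fold higher number from compound 1 to compound 3 (2.09 log units; beyond the scatter). The second added the formyl group, which compound 4 keeps. In this assay no step beyond the scatter is therefore expected, and the estimated step is a number no higher from compound 3 to compound 4 (the limit leaves the size open). For compound 4 the estimated value is 10000 nM, with an expected range of 2500 nM to 30000 nM.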

Compound 4, half-maximal inhibitory concentration: 1120 nM
Compound 4: the middle estimate sits 8.9-fold (0.95 log units) above what was measured; the whole stated range lies above it.
By their numbers in this assay, from the lowest: compound 1; then compound 4; then compound 2. At a limit, above all of these: compound 3.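

In this assay, the aromatic nitrogen is a position that responds to a single methyl, with the formyl group kept: an at least 8.9-fold lower number from compound 3 to compound 4 (0.95 log units; beyond the scatter). Among these compounds, the earlier steps touched only the oxygen substituent and the aromatic carbon, so this is the first sign that this nitrogen matters. Compound 3 stands at a limit of the assay, not at a number, so the step has no upper size: the limit of > 10000 nM in this assay, at which 1 of the 4 values shown sits.

As far as these compounds go, whether methyl on this nitrogen has any such effect without the formyl group stays open. So does what a longer chain or an amine on this nitrogen would give.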